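Swapping piperidin-1-yl for 1H-pyrazol-4-yl on compound 3

The source may hold more compounds than are shown below. What is called first, only, known or untested is meant among the compounds shown, and "the series" means these compounds.

Values in a physicochemical assay for solubility, in phosphate buffer, measured as kinetic solubility, at pH 7.4; on this read-out higher numbers stand for higher solubility and lower numbers for lower solubility:
- compound 1 `O=c1[nH]ccc2c(NC3CCCCC3)ncnc12`: 225000 nM
- compound 2 `O=c1[nH]ccc2c(NC3CCCC3)ncnc12`: 318000 nM
- compound 3 `N#C[C@H]1CCC[C@H]1Nc1nc(N2CCCCC2)nc2c(=O)[nH]ccc12`: 8600 nM

Compound 3 gives the lowest of the three numbers, 8600 nM, with the other two beyond the scatter above it. Compound 4 `N#C[C@H]1CCC[C@H]1Nc1nc(-c2cn[nH]c2)nc2c(=O)[nH]ccc12` carries the change (1H-pyrazol-4-yl in place of piperidin-1-yl on an aromatic carbon), which puts 1H-pyrazol-4-yl in place of piperidin-1-yl on an aromatic carbon. For the measured compounds named here, the only measured step, a 1.4-fold higher number from compound 1 to compound 2 (0.15 log units; within the scatter), is a swap of cyclopentyl for cyclohexyl on a nitrogen, so it does not test this place. No step beyond the scatter is therefore expected in this assay. The expected step is a 1.4-fold higher number from compound 3 to compound 4 (0.14 log units; within the scatter). Compound 4 is estimated at 12000 nM, with an expected range of 3000 nM to 50000 nM.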

Compound 4, solubility: 24000 nM
For compound 4 the middle estimate is 2.0-fold (0.30 log units) below the measured one, within the range that was stated.
By their numbers in this assay, from the lowest: compound 3; then compound 4; then compounds 1 and 2 (each within the scatter of the next).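

In this assay the aromatic carbon between two ring nitrogen atoms is sensitive to its substituent, with 1H-pyrazol-4-yl in place of piperidin-1-yl giving a 2.8-fold higher number from compound 3 to compound 4 (0.45 log units; beyond the scatter) in this series. For the compounds shown here, the earlier cycloalkyl swap on a nitrogen stayed within the scatter, so this modest step is the first single-place change to exceed it. No measurement available here bears on the origin of this step. As far as these compounds go, whether a saturated ring such as morpholin-4-yl or an open-chain dimethylamino group at this carbon would behave like piperidin-1-yl or like 1H-pyrazol-4-yl remains open. Also open, from the compounds shown here alone, is whether the step holds without the (2-cyanocyclopentyl)amino group.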